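Halogen Swap on the Thiourea Aryl Ring: Chloro to Fluoro

The source may report more compounds than this note shows. Statements on the series, on what has been measured and on what is new or still open speak of the compounds shown alone.

Compound 1 `Cc1ccc(NC(=S)NC(=O)c2cn(-c3ccccc3)nc2-c2ccc(F)cc2)cc1` gives 5440 nM in a functional assay on MCF7 cells (Homo sapiens) for inhibition, read by CCK-8 assay, with a stated time of 48 h; a lower number here means a stronger inhibitor, a higher number a weaker inhibitor.
Compound 2 `COc1ccc(-c2nn(-c3ccccc3)cc2C(=O)NC(=S)Nc2ccc(F)cc2)cc1` gives 4990 nM in this assay.
Compound 3 `O=C(NC(=S)Nc1ccc(Cl)cc1)c1cn(-c2ccccc2)nc1-c1ccc(F)cc1` gives 5470 nM in this assay.

Compound 3 has the highest of the three numbers, but both neighbours sit within the scatter of it: compound 1 at the same level, compound 2 only slightly lower. Compound 4 `O=C(NC(=S)Nc1ccc(F)cc1)c1cn(-c2ccccc2)nc1-c1ccc(F)cc1` differs from compound 3 in one place: fluoro in place of chloro on an aromatic carbon. Within the data shown here, the one measured step at this ring, a 1.0-fold higher number from compound 1 to compound 3 (0.00 log units; within the scatter), changed nothing beyond the scatter. Compound 2 also carries fluoro on this ring, yet differs elsewhere too, so its value can only show that such compounds land in the same region. The step from compound 3 to compound 4 is therefore expected to be flat, a 1.0-fold lower number from compound 3 to compound 4 (0.01 log units; within the scatter). Compound 4 is estimated at 5300 nM, in the range 2600 nM to 10800 nM.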

Compound 4, half-maximal inhibitory concentration: 5610 nM
Beside the measured number, compound 4's estimate is 1.1-fold (0.02 log units) below it; the measured number falls inside the stated range.
By their numbers in this assay, from the lowest: compounds 2, 1, 3 and 4 (each within the scatter of the next).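

With methyl, chloro and fluoro now compared on this aromatic carbon, the number stays flat: a 1.0-fold higher number from compound 3 to compound 4 (0.01 log units; within the scatter) and a 1.0-fold higher number from compound 1 to compound 4 (0.01 log units; within the scatter). A second place in the molecule behaves alike, as fluoro in place of methoxy gives a 1.1-fold higher number from compound 2 to compound 4 (0.05 log units; within the scatter). Nothing measured here accounts for this flatness.

Still open, from the compounds shown here alone, is whether an amine or a carboxylic acid on this carbon would move the number in this assay. Also open, going by these compounds, is whether replacing the thiourea link with a plain urea would shift it.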